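This account rests on a few compounds, and the source may have more. Where it says the series, first, only, none or still open, it means among the compounds named here.

Working notes on the series. In a functional assay on MIA PaCa-2 cells (Homo sapiens) for inhibition, read by MTT assay, with a stated time of 48 h, tested at 10 uM (on this read-out higher numbers stand for more inhibition of growth at the one concentration tested and lower numbers for less inhibition of growth), compound 1 (`Cc1cc(=O)c2c(O)cc(OCc3ccccc3Br)c([C@H]3CCN(C)C[C@H]3O)c2o1`) gives 30% and compound 2 (`CN1CC[C@H](c2c(O)cc(O)c3c(=O)cc(/C=C/c4ccc(Cl)cc4)oc23)[C@H](O)C1`) gives 88%. Compound 2 therefore holds the higher of the two numbers, with a gap to compound 1 that lies beyond the scatter. Compound 3 (`CN1CC[C@H](c2c(O)cc(O)c3c(=O)cc(/C=C/c4ccccc4Cl)oc23)[C@H](O)C1`) is not yet measured and differs from compound 2 in one place: 2-chlorophenyl in place of 4-chlorophenyl on a double-bonded chain carbon bound to a double-bonded chain carbon. Within the data shown here, no measured step covers this change, so only a small loss, close to the scatter, is expected. The estimated change is a number 10 percentage points lower from compound 2 to compound 3 (within the scatter). The expected value for compound 3 is 78%, with an estimated range of 55% to 95%.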

Compound 3, percent growth inhibition at one concentration: 59%
Estimate against measurement, compound 3: 19 percentage points above, and the stated range covers the measured number.
By their numbers in this assay, from the lowest: compound 1; then compound 3; then compound 2.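

In this assay, 2-chlorophenyl in place of 4-chlorophenyl on a double-bonded chain carbon bound to a double-bonded chain carbon gives a number 29 percentage points lower from compound 2 to compound 3 (beyond the scatter). The groups that leave and enter have the same atoms and the same counts, so the place of the chlorine on the phenyl ring alone separates these two values. Nothing on hand explains this loss. As far as these compounds go, whether 2-bromophenyl and 4-bromophenyl on the same chain carbon would show a similar gap remains open. So does the effect of an amine or a carboxylic acid on that phenyl ring.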